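The source may hold more compounds than are shown below. What is called first, only, known or untested is meant among the compounds shown, and "the series" means these compounds.

Measured compounds:
- compound 1, `CCCCCCCCCCCC(=O)OC[C@H](CSC[C@@H](N)C(=O)NCCO)OC(=O)CCCCCCCCCCC`: 24 nM
- compound 2, `CCCCCCCCCCCC(=O)OC[C@H](CSC[C@@H](N)C(=O)N[C@H](C)CO)OC(=O)CCCCCCCCCCC`: 22200 nM
- compound 3, `CCCCCCCCCCCC(=O)OC[C@H](CSC[C@@H](N)C(=O)NC(CC)COC)OC(=O)CCCCCCCCCCC`: 71.8 nM

In an assay on HEK293 cells for agonist activity at Toll-like receptor 2 (Homo sapiens) (on this read-out higher numbers stand for an effect only at larger amounts of compound and lower numbers for an effect already at smaller amounts), compound 3 stands second highest of the three numbers; its nearest neighbour is compound 1, shown by a 3.0-fold higher number from compound 1 to compound 3 (0.48 log units; beyond the scatter), and its furthest is compound 2, shown by a 310-fold lower number from compound 2 to compound 3 (2.49 log units; beyond the scatter). All three share the same core and differ only in the group on the amide-type nitrogen.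

Compound 4, `CCCCCCCCCCCC(=O)OC[C@H](CSC[C@@H](N)C(=O)NCCCN)OC(=O)CCCCCCCCCCC`, has not yet been measured. Its change from compound 3 is 3-aminopropyl in place of 1-(methoxymethyl)propyl on an amide-type nitrogen.

Among the compounds with values here, two measured steps bear on this. The change from a 2-hydroxyethyl to a 1-(hydroxymethyl)ethyl group gave a 930-fold higher number from compound 1 to compound 2 (2.97 log units; beyond the scatter), a large move, whereas the change from 2-hydroxyethyl to 1-(methoxymethyl)propyl gave only a 3.0-fold higher number from compound 1 to compound 3 (0.48 log units; beyond the scatter). The 3-aminopropyl group of compound 4, a plain chain carrying a donor and an acceptor, resembles the 2-hydroxyethyl group of compound 1 more than it resembles the groups of compound 2 or compound 3, so a number near that of compound 1 is expected. For compound 4 the expected step is a 2.4-fold lower number from compound 3 to compound 4 (0.38 log units; beyond the scatter), a modest fall. Compound 4 is therefore estimated at 30 nM, with a range from 6 nM to 150 nM.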

Compound 4, half-maximal effective concentration: 1960 nM
Compound 4: middle estimate off by 65-fold (1.82 log units), on the low side; the whole stated range lies below it.
By their numbers in this assay, from the lowest: compound 1; then compound 3; then compound 4; then compound 2.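

In this assay the unbranched 3-aminopropyl group gives an 82-fold higher number from compound 1 to compound 4 (1.91 log units; beyond the scatter) and so does not behave like the 2-hydroxyethyl group, which shows that this position on the amide-type nitrogen responds strongly to the chain's length and end group, not only to the methyl branch seen earlier. The same group gives a 27-fold higher number from compound 3 to compound 4 (1.44 log units; beyond the scatter) and also an 11-fold lower number from compound 2 to compound 4 (1.05 log units; beyond the scatter), placing compound 4 between the branched groups of compound 3 and compound 2 on this read-out. No measurement offered here explains these steps.

Compound 4 differs from compound 1 in both chain length and end group, so the two effects cannot be separated. A 3-hydroxypropyl or a 2-aminoethyl group on the same nitrogen would change only one of them.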